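The compounds below may be only part of what the source reports. "The series", "measured", "known", "first", "only" and "open" are said of these compounds alone.

Measured so far in a physicochemical assay for solubility, at pH 1.1; a higher number here means a more soluble compound, a lower number a less soluble compound:

Compound 1, `Cc1cc(CN(CC2CC2)C(CC(=O)O)c2ccc(Cl)cc2)ccc1OCCn1c(=O)ccn(C)c1=O`: 3000000 nM
Compound 2, `Cc1cc(CN(C2CCC2)C(CC(=O)O)c2ccc(Cl)cc2)ccc1OCCn1c(=O)ccn(C)c1=O`: 3000000 nM
Compound 3, `COc1cc(CN(CC2CC2)C(CC(=O)O)c2ccc(Cl)cc2)ccc1OCCn1c(=O)ccn(C)c1=O`: 3000000 nM

Working notes. Compound 2 is made from compound 1 by one change, (cyclobutyl in place of cyclopropylmethyl on an amine nitrogen). The step it made in this assay is no change at the digits printed from compound 1 to compound 2 (within the scatter). Compound 3 differs from compound 1 in the core, (methoxy in place of methyl on an aromatic carbon), and the step from that change is no change at the digits printed from compound 1 to compound 3 (within the scatter). All three measured compounds therefore stand level with one another at the digits reported, and no order among them can be read from these three values.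

Compound 4, `COc1cc(CN(C2CCC2)C(CC(=O)O)c2ccc(Cl)cc2)ccc1OCCn1c(=O)ccn(C)c1=O`, has not yet been measured in this assay. It is made from compound 3 by cyclobutyl in place of cyclopropylmethyl on an amine nitrogen. The place is the same as for the change from compound 1 to compound 2, an amine nitrogen whose other neighbours are a saturated chain carbon and a saturated chain carbon, so the change is the same one, seen here a second time but on the core of compound 3 rather than that of compound 1.

For the measured compounds named here, the expectation for compound 4 rests on the one earlier instance of this change: the step from compound 1 to compound 2 was no change at the digits printed from compound 1 to compound 2 (within the scatter), and the core change from compound 1 to compound 3 also gave no change at the digits printed from compound 1 to compound 3 (within the scatter). Going by the values given here, with nothing among the measured compounds pointing the other way, the step from compound 3 to compound 4 is estimated as no change at the digits printed from compound 3 to compound 4 (within the scatter). Compound 4 is accordingly expected to come in at about 3000000 nM, with a likely range estimated from 1500000 nM to 6000000 nM.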

Compound 4, solubility: 3000000 nM
Compound 4: the middle estimate sits on the measured number at the digits printed, within the range that was stated.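

In this assay, cyclobutyl in place of cyclopropylmethyl on an amine nitrogen gives no change at the digits printed from compound 3 to compound 4 (within the scatter) and, on the core of compound 1, gives no change at the digits printed from compound 1 to compound 2 (within the scatter) so the change reads the same on both cores shown. Methoxy in place of methyl on an aromatic carbon reads the same way whichever amine group is present, with no change at the digits printed from compound 2 to compound 4 (within the scatter) alongside no change at the digits printed from compound 1 to compound 3 (within the scatter) and compound 4 printing 3000000 nM level with the other three compounds. This shows that the two changes combine without any step at the digits printed, but two cores that differ only by methyl and methoxy do not show that the cyclobutyl change would carry to more distant cores, and no measurement shown accounts for the level values.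

Going by these compounds, whether a longer chain such as hexyl, or a primary amine, in the same place on the amine nitrogen would stand level with these four compounds remains open. Also open, on these data alone, is whether a core with a group other than methyl or methoxy on that aromatic carbon, such as a nitrile, would keep the cyclobutyl change as flat as it is here.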